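Methoxy placement on the aryl ketone of the chalcone series

The source may hold more compounds than are shown below. What is called first, only, known or untested is meant among the compounds shown, and "the series" means these compounds.

Measured so far:
- compound 1 `O=C(/C=C/c1cn(-c2ccccc2)nc1-c1ccncc1)c1ccccc1`: in a functional assay on Huh-7 cells (Homo sapiens) for inhibition, read by sulforhodamine B assay, with a stated time of 72 h (on this read-out higher numbers stand for weaker inhibition and lower numbers for stronger inhibition), compound 1 gives 1800 nM
- compound 2 `COc1cc(OC)c(C(=O)/C=C/c2cn(-c3ccccc3)nc2-c2ccncc2)c(OC)c1`: in this assay compound 2 gives 2600 nM
- compound 3 `COc1ccc(C(=O)/C=C/c2cn(-c3ccccc3)nc2-c2ccncc2)cc1OC`: in this assay compound 3 gives 2000 nM

All three share the same core and differ only in the aryl group on the carbonyl carbon. Compound 3 stands second highest of the three numbers; its nearest neighbour is compound 1, and compound 2 is furthest, but both gaps lie within the scatter, so no order among the three can be read from these data.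

Compound 4 `COc1ccc(C(=O)/C=C/c2cn(-c3ccccc3)nc2-c2ccncc2)c(OC)c1` is not yet measured. It differs from compound 3 only in this: 2,4-dimethoxyphenyl in place of 3,4-dimethoxyphenyl on a carbonyl carbon. Within the data shown here, the one measured step bearing on the aryl group is a 1.1-fold higher number from compound 1 to compound 3 (0.05 log units; within the scatter), which added two methoxy groups to a bare phenyl without moving the number beyond the scatter; compound 2, with three methoxy groups, gives a number in the same band. Among the measured compounds shown here, no step among the measured compounds moves a methoxy group from one place to another, so the move itself is untested. Given that every change of the aryl group so far has left the number unchanged within the scatter, compound 4 is expected to behave likewise, with an estimated step of no change at the digits printed from compound 3 to compound 4 (within the scatter) of essentially nothing beyond the scatter. The estimate for compound 4 in this assay is 2000 nM, with a range from 900 nM to 4500 nM.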

Compound 4, half-maximal inhibitory concentration: 4400 nM
For compound 4 the middle estimate is 2.2-fold (0.34 log units) below the measured one; the measured number falls inside the stated range.
By their numbers in this assay, from the lowest: compounds 1, 3, 2 and 4 (each within the scatter of the next, the first and the last beyond it).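

In this assay, among these compounds, 2,4-dimethoxyphenyl in place of 3,4-dimethoxyphenyl on the carbonyl carbon gives a 2.2-fold higher number from compound 3 to compound 4 (0.34 log units; beyond the scatter), the first aryl change here to pass the scatter, with the atoms of the group unchanged, so the arrangement of the methoxy groups can matter even though adding them to phenyl in compound 3 did not. Against bare phenyl, 2,4-dimethoxyphenyl gives a 2.4-fold higher number from compound 1 to compound 4 (0.39 log units; beyond the scatter), while hydrogen in place of methoxy on an aromatic carbon gives a 1.7-fold higher number from compound 2 to compound 4 (0.23 log units; within the scatter), so that the third methoxy group of compound 2 shows no separable effect. Nothing available explains why the arrangement of the methoxy groups changes the number.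

On these data alone, whether a single methoxy group would produce part of this step remains open. So does the outcome with an amine or a carboxylic acid on the aryl ring in place of methoxy.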